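Swapping Cyclopentyl for a Trifluoromethylphenyl Group

The source may report more compounds than this note shows. Statements on the series, on what has been measured and on what is new or still open speak of the compounds shown alone.

Measured so far in an assay on CHO-K1 cells for displacement of a labelled ligand from adenosine receptor A1 (Homo sapiens), read by scintillation counting, with a stated time of 60 min; on this read-out lower numbers stand for stronger inhibition and higher numbers for weaker inhibition:
Compound 1 `Nc1nc(N/N=C/c2ccc(Cl)c(C(F)(F)F)c2)nc2c1ncn2[C@@H]1O[C@H](CO)[C@@H](O)[C@H]1O` reaches only the limit of the assay, > 10000 nM.
Compound 2 `Nc1nc(N/N=C/c2cccnc2Cl)nc2c1ncn2[C@@H]1O[C@H](CO)[C@@H](O)[C@H]1O` gives 4.6 nM.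
Compound 3 `Nc1nc(N/N=C/C2CCCC2)nc2c1ncn2[C@@H]1O[C@H](CO)[C@@H](O)[C@H]1O` gives 5.6 nM.

Compound 3 holds the higher of the two real numbers, and its nearest neighbour is compound 2, a gap within the scatter: a 1.2-fold higher number from compound 2 to compound 3 (0.09 log units; within the scatter). Compound 4 `Nc1nc(N/N=C/c2ccc(C(F)(F)F)cc2)nc2c1ncn2[C@@H]1O[C@H](CO)[C@@H](O)[C@H]1O` differs from compound 3 in one place: 4-(trifluoromethyl)phenyl in place of cyclopentyl on a carbon with a double bond to nitrogen. Among the measured compounds shown here, two measured steps bear on this position. an at least 2100-fold lower number from compound 1 to compound 2 (3.33 log units; beyond the scatter) and an at least 1700-fold lower number from compound 1 to compound 3 (3.25 log units; beyond the scatter) show that 4-chloro-3-(trifluoromethyl)phenyl sits at the limit of > 10000 nM in this assay, at which 1 of the 3 values shown sits, while 2-chloropyridin-3-yl and cyclopentyl do not. Compound 4 keeps the trifluoromethyl of compound 1 but not its chlorine, so a weakening step is expected, an 89-fold higher number from compound 3 to compound 4 (1.95 log units; beyond the scatter), with wide uncertainty. Compound 4 is estimated at 500 nM, between 20 nM and 10000 nM.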

Compound 4, inhibition constant: 37 nM
Compound 4: the middle estimate sits 14-fold (1.13 log units) above what was measured; measured number inside the range.
By their numbers in this assay, from the lowest: compounds 2 and 3 (each within the scatter of the next); then compound 4. At a limit, above all of these: compound 1.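

In this assay, a phenyl ring bearing trifluoromethyl can keep binding at this position: an at least 270-fold lower number from compound 1 to compound 4 (2.43 log units; beyond the scatter), so the trifluoromethyl group alone does not produce the loss seen with compound 1. The change from the other two groups still has a cost: a 6.6-fold higher number from compound 3 to compound 4 (0.82 log units; beyond the scatter) and an 8.0-fold higher number from compound 2 to compound 4 (0.91 log units; beyond the scatter). Compound 1 alone remains at a limit of the assay: the limit of > 10000 nM in this assay, at which 1 of the 4 values shown sits.

Whether the chlorine of compound 1 or the different placing of its trifluoromethyl accounts for that limit stays open. So does the effect of an amine or a carboxylic acid on the phenyl ring.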